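The source may hold more compounds than are shown below. What is called first, only, known or untested is meant among the compounds shown, and "the series" means these compounds.

Measured so far:
compound 1, `C#CCOc1ccc2oc(=O)ccc2c1`, 24000 nM in a functional assay on A549 cells (Homo sapiens) for cytotoxicity, read by MTT assay, with a stated time of 48 h; on this read-out lower numbers stand for stronger inhibition and higher numbers for weaker inhibition
compound 2, `O=c1ccc2cc(OCc3cn(-c4cccc(CO)c4)nn3)ccc2o1`, 35100 nM in this assay

Compound 2 gives the larger of the two numbers, but its distance to compound 1 is within the scatter of repeated measurements, so the two values are read as one level. Both carry the same core and differ in what sits on the ether oxygen.

Compound 3, `O=c1ccc2cc(OCc3cn(-c4ccc([N+](=O)[O-])cc4)nn3)ccc2o1`, is not yet measured. It differs from compound 2 in one place: 4-nitrophenyl in place of 3-(hydroxymethyl)phenyl on an aromatic nitrogen. Among the compounds with values here, no pair of measured compounds shows what such a swap does here, so there is no step to lean on. With compound 2 at 35100 nM and compound 1 at the same level, the step of a 1.4-fold lower number from compound 2 to compound 3 (0.15 log units; within the scatter) is expected to stay within the scatter, at most a modest move toward a lower number. Compound 3 is accordingly estimated at 25000 nM, with a range from 8000 nM to 80000 nM.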

Compound 3, half-maximal inhibitory concentration: 33600 nM
Compound 3: middle estimate off by 1.3-fold (0.13 log units), on the low side; the range from low to high includes it.
By their numbers in this assay, from the lowest: compounds 1, 3 and 2 (each within the scatter of the next).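

In this assay, within the data shown here, the exchange of 3-(hydroxymethyl)phenyl for 4-nitrophenyl on the aromatic nitrogen gives the first step that can be read at this position: a 1.0-fold lower number from compound 2 to compound 3 (0.02 log units; within the scatter). The two groups differ in where they are attached on the phenyl ring and in their counts, with 1 hydrogen-bond donor leaving and 0 hydrogen-bond donors entering, yet the two compounds stand at one level. Nothing given here accounts for that level.

The compounds shown leave open whether any group on this nitrogen can shift the number beyond the scatter, as both carry a substituted phenyl there. A carboxylic acid or an amine on that phenyl ring, or a longer alkyl chain in place of the ring, would put this to the test.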